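Filling an open aromatic position on compound 3

This account rests on a few compounds, and the source may have more. Where it says the series, first, only, none or still open, it means among the compounds named here.

Three measured compounds share one core. Compound 1 `Cc1cccc(NNS(=O)(=O)c2ccc(C(=O)NCC(=O)O)cc2)c1` gives 80 nM in an assay for inhibition of Indoleamine 2,3-dioxygenase 1 (Homo sapiens), read by spectrophotometry, with stated times of 1 h and 4 h; on this read-out lower numbers stand for stronger inhibition and higher numbers for weaker inhibition. Compound 2 `CC(=O)Nc1ccc(S(=O)(=O)NNc2ccc(F)c(Br)c2)cc1` gives 128 nM in this assay. Compound 3 `O=S(=O)(NNc1ccc(Br)cc1)c1ccccc1` gives 172 nM in this assay, the highest of the three numbers: compound 2 lies within the scatter of it, while compound 1 sits beyond the scatter at a lower number. Compound 4 `COC(=O)CCc1ccc(S(=O)(=O)NNc2ccc(Br)cc2)cc1` differs from compound 3 by 2-(methoxycarbonyl)ethyl in place of hydrogen on an aromatic carbon. Because compound 1 returns 80 nM with a larger group on its own ring, a modest move downward is expected. The step from compound 3 to compound 4 is expected to be a 1.6-fold lower number from compound 3 to compound 4 (0.19 log units; within the scatter), barely beyond the scatter. Compound 4 is estimated at 110 nM, ranging from 45 nM to 280 nM.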

Compound 4, half-maximal inhibitory concentration: 121 nM
Compound 4: middle estimate off by 1.1-fold (0.04 log units), on the low side; the measured number falls inside the stated range.
By their numbers in this assay, from the lowest: compounds 1, 4, 2 and 3 (each within the scatter of the next, the first and the last beyond it).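

In this assay, placing 2-(methoxycarbonyl)ethyl on an aromatic carbon para to a large group gives a 1.4-fold lower number from compound 3 to compound 4 (0.15 log units; within the scatter). Among these compounds, this is the first comparison in the set that differs in one place, and it shows that this position accepts a chain of this size while the two numbers stay within the scatter of each other. No available evidence bears on the reason for this result. The compounds shown leave open whether the corresponding carboxylic acid, an amine or a longer chain at this position would move the number beyond the scatter.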